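Swapping amino for hydroxy on the side chain

The source may report more compounds than this note shows. Statements on the series, on what has been measured and on what is new or still open speak of the compounds shown alone.

In a functional assay on MCF7 cells (Homo sapiens) for antiproliferative activity, read by MTT assay, with a stated time of 24 h (on this read-out lower numbers stand for stronger inhibition and higher numbers for weaker inhibition), compound 1 `CCn1c(C(=O)N[C@H](C)C(=O)OC)ccc1C(CC)(CC)c1ccc(OCS(=O)(=O)c2ccccc2)c(C)c1` gives > 50000 nM, which is a limit of the assay and not a number. Compound 2 `CCn1c(C(=O)NCCC(=O)OC)ccc1C(CC)(CC)c1ccc(OCS(=O)(=O)c2ccccc2)c(C)c1` gives > 50000 nM, which is also a limit. Among the measured compounds shown here, compound 3 `CCn1c(C(=O)NCCN)ccc1C(CC)(CC)c1ccc(OCS(=O)(=O)c2ccccc2)c(C)c1` gives 6470 nM, the only true number of the three.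

Compound 4 `CCn1c(C(=O)NCCO)ccc1C(CC)(CC)c1ccc(OCS(=O)(=O)c2ccccc2)c(C)c1` differs from compound 3 at a single place hydroxy in place of amino on a saturated chain carbon, two bonds along the chain from an amide-type nitrogen.

For the measured compounds named here, two measured steps bear on this change: an at least 7.7-fold lower number from compound 2 to compound 3 (0.88 log units; beyond the scatter), with amino in place of methoxycarbonyl, and an at least 7.7-fold lower number from compound 1 to compound 3 (0.88 log units; beyond the scatter). Going by the values given here, both reach compound 3 and its amino group, but no hydroxy compound has been measured, so the guide is indirect. Removing the amino group is expected to move the result back toward weaker inhibition, with an estimated change of a 3.4-fold higher number from compound 3 to compound 4 (0.53 log units; beyond the scatter). For compound 4 the expected value in this assay is 22000 nM, within an estimated range of 8000 nM to 50000 nM.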

Compound 4, half-maximal inhibitory concentration: 15500 nM
Compound 4: middle estimate off by 1.4-fold (0.15 log units), on the high side; the measured number falls inside the stated range.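

In this assay, among the compounds shown here, amino is not the only end group on this side chain that gives a true number: hydroxy does too, although a 2.4-fold higher number from compound 3 to compound 4 (0.38 log units; beyond the scatter) shows that it gives back part of the gain. Measured against the two methyl esters, the 2-hydroxyethyl side chain still gives stronger inhibition, with an at least 3.2-fold lower number from compound 2 to compound 4 (0.50 log units; beyond the scatter) and an at least 3.2-fold lower number from compound 1 to compound 4 (0.50 log units; beyond the scatter). These last two steps are open-ended, as compound 1 and compound 2 each sit at a limit of the assay and not at a number: the limit of > 50000 nM in this assay, at which 2 of the 4 values shown sit.

On these data alone, how a carboxylic acid, a dimethylamino group or a longer chain ending in amino would read at this position stays open. Also open, as far as these compounds go, is whether the gap between amino and hydroxy would hold in other cell lines or at other exposure times.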